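A few compounds are considered here, and "the series" means these few. Any claim that something is new, unique, unknown or untested is made for them only; others in the source may bear on it.

Measured in a physicochemical assay for lipophilicity; a higher number here means a more lipophilic compound, a lower number a more polar compound:
Compound 1 `C[C@H]1CC[C@@H]2[C@@H](OC(=O)[C@]23CC(c2ccc(Cl)cc2)N(c2ccccc2)O3)[C@]2(C)C(=O)C=C[C@@]12O`: 3.87
Compound 2 `C[C@H]1CC[C@@H]2[C@@H](OC(=O)[C@]23CC(c2ccc(C#N)cc2)N(c2ccccc2)O3)[C@]2(C)C(=O)C=C[C@@]12O`: 2.94
Compound 3 `C[C@H]1CC[C@@H]2[C@@H](OC(=O)[C@]23CC(c2cccc(F)c2)N(c2ccccc2)O3)[C@]2(C)C(=O)C=C[C@@]12O`: 3.35

Compound 3, at 3.35, holds the second highest of the three numbers, under compound 1 and over compound 2. Compound 4 `C[C@H]1CC[C@@H]2[C@@H](OC(=O)[C@]23CC(c2ccccc2F)N(c2ccccc2)O3)[C@]2(C)C(=O)C=C[C@@]12O` carries 2-fluorophenyl in place of 3-fluorophenyl on a saturated ring carbon. Two measured steps change the group on that carbon: a number 0.52 log units lower from compound 1 to compound 3 (beyond the scatter) and a number 0.41 log units higher from compound 2 to compound 3 (beyond the scatter). Both are modest and beyond the scatter, but neither compares two fluorophenyl groups, and the data hold no such comparison. In this assay, no step beyond the scatter is therefore expected, and the estimated change is a number 0.05 log units lower from compound 3 to compound 4 (within the scatter). For compound 4 the estimated value is 3.3, with an expected range from 3 to 3.62.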

Compound 4, partition coefficient: 3.35
The estimate for compound 4 lay 0.05 log units below the measured number, within the range that was stated.
By their numbers in this assay, from the lowest: compound 2; then compounds 3 and 4 (each within the scatter of the next); then compound 1.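

In this assay, within the data shown here, 2-fluorophenyl in place of 3-fluorophenyl on this saturated ring carbon gives no change at the digits printed from compound 3 to compound 4 (within the scatter), the first direct comparison of two fluorophenyl groups at this position. The other two groups at this carbon stand apart from the 2-fluorophenyl group as well, with a number 0.41 log units higher from compound 2 to compound 4 (beyond the scatter) and a number 0.52 log units lower from compound 1 to compound 4 (beyond the scatter). No measurement shown offers an explanation for this result. The compounds shown leave open whether a methoxy group or an amine on this aromatic ring would likewise leave the number unchanged, and what a pyridyl group would do at this carbon.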